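The source may report more compounds than this note shows. Statements on the series, on what has been measured and on what is new or still open speak of the compounds shown alone.

Compound 2 `CCOC(=O)CCCCCOc1cccc(CN(C(=O)c2ccc(-c3cnc(OC)nc3OC)cc2)C(C)C)c1` is the starting point here, and its measurement in an ADME assay on BJ cells (Homo sapiens) for cytotoxicity, read by CellTiter-Glo and resazurin assay, with a stated time of 72 h (a higher number here means that more compound is needed for the effect, a lower number that less compound is needed), is only a limit of the assay: compound 2 gives > 26000 nM. Compound 1 `CCOC(=O)CCCCCOc1cccc(CN(C(=O)c2ccc(-c3cccc(NC(C)=O)c3)cc2)C(C)C)c1` is its nearest measured neighbour; in this assay compound 1 likewise gives only a limit, > 26000 nM. The step that the two limits leave unreadable from compound 1 to compound 2 therefore has no readable size, since both values sit at the same limit (the limit of > 26000 nM in this assay, at which 2 of the 2 values shown sit). The compound not yet measured is compound 3 `CCOC(=O)CCCCCOc1cccc(CN(C(=O)c2ccc(-c3cccc(-c4nnc(C)o4)c3)cc2)C(C)C)c1`. Its change from compound 2 is described as follows: 3-(5-methyl-1,3,4-oxadiazol-2-yl)phenyl in place of 2,4-dimethoxypyrimidin-5-yl on an aromatic carbon. Among the measured compounds shown here, no measured step shows how such a swap moves the read-out; the only evidence is the limit of > 26000 nM in this assay, at which 2 of the 2 values shown sit, where both measured compounds sit. The expectation for compound 3 is therefore another value at or past that limit, with the step that the limit leaves unreadable from compound 2 to compound 3 expected to be small. Compound 3 is estimated at 40000 nM, between 15000 nM and 120000 nM.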

Compound 3, half-maximal effective concentration: > 26000 nM
Compound 3: a limit, no number; the forecaster's own chance of this, stated with the estimate: 85%; the middle value does not contradict the limit.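

In this assay compound 3 gives > 26000 nM as a limit of the assay, so the steps to it from compound 1 and compound 2 cannot be read. Still open is whether the groups swapped here differ at all in this read-out, because all three compounds stop at the same point: the limit of > 26000 nM in this assay, at which 3 of the 3 values shown sit.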